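One Methyl Less on the Shared Core

A few compounds are considered here, and "the series" means these few. Any claim that something is new, unique, unknown or untested is made for them only; others in the source may bear on it.

Three measured compounds share one core and differ only in the small groups on a six-membered aromatic ring with one nitrogen. Compound 1 is `COc1cnc(C[S+]([O-])c2nc3cc(OC(F)F)ccc3[nH]2)cc1OC`, compound 2 is `COc1cnc(C[S+]([O-])c2nc3cc(OC(F)F)ccc3[nH]2)c(C)c1OC`, and compound 3 is `COc1c(C)cnc(C[S+]([O-])c2nc3cc(OC(F)F)ccc3[nH]2)c1C`. In an ADME assay, at pH 5 (on this read-out higher numbers stand for a longer-lived compound and lower numbers for a shorter-lived compound), compound 1 gives 2.1 h, compound 2 gives 3.7 h, and compound 3 gives 1.9 h. Compound 2 and compound 1 differ by hydrogen in place of methyl on an aromatic carbon and the measured step is a 1.8-fold lower number from compound 2 to compound 1 (0.25 log units; within the scatter). Compound 2 and compound 3 differ by methyl in place of methoxy on an aromatic carbon, with a step of a 1.9-fold lower number from compound 2 to compound 3 (0.29 log units; within the scatter). Compound 3 and compound 1 show two values that lie within the scatter of each other.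

Compound 4, `COc1ccnc(C[S+]([O-])c2nc3cc(OC(F)F)ccc3[nH]2)c1C`, is not yet measured. It differs from compound 3 by hydrogen in place of methyl on an aromatic carbon. Among the compounds with values here, this is the same kind of change as the one from compound 2 to compound 1, but the surroundings are not identical: in compound 2 the methyl that leaves sits ortho to a large group and meta to a methoxy group, whereas in compound 3 it sits meta to a methyl group and para to a large group. Within the data shown here, the expected step in this assay is a 1.4-fold lower number from compound 3 to compound 4 (0.13 log units; within the scatter), resting on the single measured example of this kind of change, a 1.8-fold lower number from compound 2 to compound 1 (0.25 log units; within the scatter), which stayed within the scatter. Compound 4 is therefore estimated to give 1.4 h in this assay, with a likely range from 0.7 h to 2.8 h.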

Compound 4, half-life: 0.17 h
Compound 4: middle estimate off by 8.2-fold (0.92 log units), on the high side, and the stated range ends above it.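

In this assay, hydrogen in place of methyl on an aromatic carbon gives an 11-fold lower number from compound 3 to compound 4 (1.05 log units; beyond the scatter), and taking a methoxy group off the ring gives a 22-fold lower number from compound 2 to compound 4 (1.34 log units; beyond the scatter). Both steps are large, and the first shows that this change does not carry a fixed size from one core to another in this series, since two examples of the same change differ by more than the scatter allows: the same change on two cores in this assay, a 1.8-fold lower number (0.25 log units; within the scatter) from compound 2 to compound 1 and an 11-fold lower number (1.05 log units; beyond the scatter) from compound 3 to compound 4, 6.3-fold (0.80 log units) apart, beyond the scatter of two such steps. Within the data shown here, this shows that the result of removing a methyl cannot simply be copied from one core to the next, but with only two examples it does not show which difference in the surroundings of that methyl sets the size of the step, nor does it give a rule for any other core.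

The compounds shown leave open whether another small group in the place of that methyl, such as a chlorine atom, an ethyl group or an amine, would stay close to compound 3 or fall towards compound 4. They also leave open whether the large step depends on the methoxy group that sits ortho to the place of change, since every compound here keeps a methoxy group on the ring.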